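The source may hold more compounds than are shown below. What is called first, only, known or untested is meant among the compounds shown, and "the series" means these compounds.

Measured compounds:
compound 1, `Nc1cc(N)c2nc(-c3ccccc3)c(Oc3ccc(Cl)c(Cl)c3)nc2c1` — in a functional assay on MOLT-4 cells (Homo sapiens) for inhibition, read by sulforhodamine B assay, with a stated time of 48 h (a higher number here means a weaker inhibitor of growth, a lower number a stronger inhibitor of growth), compound 1 gives 6310 nM
compound 2, `CCOC(=O)[C@H](CCC(=O)O)NC(=O)c1ccc(Oc2nc3cc(N)cc(N)c3nc2-c2ccccc2)cc1` — in this assay compound 2 gives 38900 nM

Of the two measured compounds, compound 1 stands at the lower number, and compound 2 lies a good way above it, a gap that goes beyond the usual scatter of repeated measurements. Compound 3, `Nc1cc(N)c2nc(-c3ccccc3)c(Sc3ccc(F)cc3)nc2c1`, has not yet been measured in this assay. It departs from compound 1 in one place: (4-fluorophenyl)sulfanyl in place of 3,4-dichlorophenoxy on an aromatic carbon. Both groups that leave and enter are single six-membered aromatic rings of carbon only, with no hydrogen-bond donor and one hydrogen-bond acceptor each, so the change is a swap of one aryl group for another of similar size on the same carbon of the shared core. Among the compounds with values here, no pair of measured compounds differs by this exact change, so the step has to be expected rather than read off. The expectation is a small step from compound 1 to compound 3, a 1.3-fold higher number from compound 1 to compound 3 (0.10 log units; within the scatter), toward a slightly higher number, not clearly beyond the scatter. Compound 3 is therefore estimated at 8000 nM, in the range 2500 nM to 25000 nM.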

Compound 3, concentration for 50% growth inhibition: < 100000 nM
Compound 3 gave a limit, no number (the forecaster's own chance of this, stated with the estimate: 5%); the middle value does not contradict the limit.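

In this assay compound 3 gives < 100000 nM, which is a limit of the assay and not a number. Within the data shown here, no step between compound 1 and compound 3 can be read from this result. The compounds shown leave open whether, and in which direction, (4-fluorophenyl)sulfanyl in place of 3,4-dichlorophenoxy on an aromatic carbon shifts growth inhibition.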